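The source may hold more compounds than are shown below. What is called first, only, known or untested is meant among the compounds shown, and "the series" means these compounds.

Working notes on the series

Two compounds have numbers in a functional assay on RXF 393 cells (Homo sapiens) for cytotoxicity, read by sulforhodamine B assay, with a stated time of 48 h; on this read-out higher numbers stand for weaker inhibition of growth and lower numbers for stronger inhibition of growth. Compound 1 `Nc1nc(Cl)c2ncn(Cc3ccc(CCl)cc3)c2n1` gives 1320 nM in this assay. Compound 2 `ClCc1ccccc1Cn1cnc2nc(Cl)nc(Cl)c21` gives 1 nM in this assay. Within the data shown here, compound 2 therefore holds the lowest of the two numbers, and the gap to compound 1, the only other measured compound, lies beyond the scatter, so compound 2 counts as the stronger growth inhibitor of the pair. Among the measured compounds shown here, compound 1 and compound 2 differ in more than one place, so no single structural step between them can be read off.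

Compound 3 `ClCc1ccccc1Cn1cnc2ncnc(Cl)c21` has not been measured. Relative to compound 2 the change is hydrogen in place of chloro on an aromatic carbon. For the measured compounds named here, no measured pair in this set shows what removing a chloro from the core does, so the direction and size of the step rest on expectation alone. A loss of one heavy atom from the core of compound 2 is expected to cost some potency rather than add to it, but not to undo the whole difference between compound 2 and compound 1. Compound 3 is expected to give 6 nM in this assay, with a range from 1 nM to 60 nM. This estimate means a step from compound 2 to compound 3 of a 6.0-fold higher number from compound 2 to compound 3 (0.78 log units; beyond the scatter), expected to be a moderate weakening.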

Compound 3, concentration for 50% growth inhibition: 1650 nM
The estimate for compound 3 lay 280-fold (2.44 log units) below the measured number, and the stated range ends below it.
By their numbers in this assay, from the lowest: compound 2; then compounds 1 and 3 (each within the scatter of the next).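

In this assay, among these compounds, hydrogen in place of chloro on the aromatic carbon between two ring nitrogen atoms gives a 1700-fold higher number from compound 2 to compound 3 (3.22 log units; beyond the scatter), the first step that can be tied to one place, and it shows that this position is far from indifferent: the loss of one chlorine atom, with no ring, no charge and no hydrogen-bond donors or acceptors counted in the change, is enough for a large step. Compound 3 keeps the chloro group that stands meta to this carbon, so that group alone does not give the low number of compound 2. No measurement shown here explains the size of this step.

The compounds shown leave open whether the low number needs chloro itself at this carbon or would also appear with another group there, such as fluoro, bromo or methoxy. As far as these compounds go, compound 1 differs from compound 2 in more than one place, so it gives no clean reading on this carbon, and the part played by the placement of the chloromethyl group on the benzene ring also remains open.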